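This account rests on a few compounds, and the source may have more. Where it says the series, first, only, none or still open, it means among the compounds named here.

For the measured compounds named here, in a functional assay on A2780 cells (Homo sapiens) for inhibition (a higher number here means a weaker inhibitor, a lower number a stronger inhibitor), compound 1 (`CCNCc1cc(-c2c(C(=O)NCC)noc2-c2cc(C(C)C)c(O)cc2O)on1`) gives 45 nM as its half-maximal inhibitory concentration, the only number in this small set. Going by the values given here, compound 2 (`CCNC(=O)c1noc(-c2cc(C(C)C)c(O)cc2O)c1-c1cc(CNCCO)no1`) has no place on that scale: the entry for compound 2 reads "not determined" (no result reported) and offers no single number, so no measured step starts from it. Compound 3 (`CCNC(=O)c1noc(-c2cc(C(C)C)c(O)cc2O)c1-c1cc(CN2CCCCC2)no1`) differs from compound 2 in one place (piperidin-1-yl in place of (2-hydroxyethyl)amino on a saturated chain carbon bound to an aromatic carbon), with piperidin-1-yl in place of (2-hydroxyethyl)amino on a saturated chain carbon bound to an aromatic carbon. Among the compounds with values here, no measured step in this assay shows what this exchange does, so no direction can be argued. The expectation is a result within the usual scatter of compound 1 at 45 nM as the sole anchor. The estimated value for compound 3 is 45 nM within an expected range of 15 nM to 130 nM in this measurement.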

Compound 3, half-maximal inhibitory concentration: 62 nM
Estimate against measurement, compound 3: 1.4-fold (0.14 log units) below, and the stated range covers the measured number.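

In this assay, piperidin-1-yl in place of ethylamino on a saturated chain carbon bound to an aromatic carbon gives a 1.4-fold higher number from compound 1 to compound 3 (0.14 log units; within the scatter). For the compounds shown here, this is the first measured step at this position, and it shows that a six-membered non-aromatic ring can stand on this chain carbon with the result staying within the scatter of the ethylamino compound. Nothing available explains why the two groups read alike.

As far as these compounds go, compound 2 has no number, so its steps cannot be read and the effect of (2-hydroxyethyl)amino at this position remains unknown. From the compounds shown here alone, with only ethylamino and piperidin-1-yl to compare, it also remains open whether a morpholin-4-yl ring, a carboxylic acid or a longer chain on this carbon would fall within the same scatter.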